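Fluoro to cyano on an aromatic ring

This account rests on a few compounds, and the source may have more. Where it says the series, first, only, none or still open, it means among the compounds named here.

In a functional assay on SF-268 cells (Homo sapiens) for antiproliferative activity, read by sulforhodamine B assay, with a stated time of 72 h (on this read-out lower numbers stand for stronger inhibition and higher numbers for weaker inhibition), the values are:
Compound 1 `O=C1CS/C(=N/Nc2nncc3ccccc23)N1c1ccccc1` gives 7 nM
Compound 2 `CCN1C(=O)CS/C1=N/Nc1nncc2ccccc12` gives 6 nM
Compound 3 `Fc1ccc(Nc2nncc3ccccc23)cc1` gives 4.5 nM

Compound 3 at 4.5 nM lies within the usual scatter of both other compounds, so the three cannot be ranked. Compound 4 `N#Cc1ccc(Nc2nncc3ccccc23)cc1` carries cyano in place of fluoro on an aromatic carbon, para to a large group (cyano in place of fluoro on an aromatic carbon). Going by the values given here, the only measured step is a 1.2-fold lower number from compound 1 to compound 2 (0.07 log units; within the scatter) and it puts ethyl in place of phenyl on an amide-type nitrogen in a ring, a different change elsewhere in the structure. Among the compounds with values here, no measured pair shows the fluoro-to-cyano swap, so the evidence is thin, and no step beyond the scatter is expected in this assay here. The estimate amounts to a 1.3-fold higher number from compound 3 to compound 4 (0.12 log units; within the scatter) and stays within the scatter. Compound 4 is estimated at 6 nM with an expected range from 2 nM to 20 nM as the likely span.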

Compound 4, half-maximal inhibitory concentration: 3.3 nM
Estimate against measurement, compound 4: 1.8-fold (0.26 log units) above, within the range that was stated.
By their numbers in this assay, from the lowest: compounds 4, 3, 2 and 1 (each within the scatter of the next, the first and the last beyond it).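

Swapping fluoro for cyano on this aromatic carbon, para to a large group, gives a 1.4-fold lower number from compound 3 to compound 4 (0.13 log units; within the scatter) in this assay, the first direct reading of this position. The swap adds a hydrogen-bond acceptor and a triple bond, yet the number does not move beyond the scatter. Nothing measured here accounts for how closely the two compounds agree.

On these data alone, an amine or a carboxylic acid on this carbon remains untested in these compounds. So does a methoxy group, and with only these two groups compared, how far this position tolerates change stays open.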